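Neopentyl in place of the alkenyl group: expected half-life

The compounds below may be only part of what the source reports. "The series", "measured", "known", "first", "only" and "open" are said of these compounds alone.

Compound 1 `CC(C)(C)CCn1nc(C2CC2)c(O)c(C2=NS(=O)(=O)c3cc(NS(C)(=O)=O)ccc3N2)c1=O`, compound 2 `CC(C)=Cc1nn(CCC(C)(C)C)c(=O)c(C2=NS(=O)(=O)c3cc(NS(C)(=O)=O)ccc3N2)c1O` and compound 3 `CC(C)CCn1nc(-c2cccs2)c(O)c(C2=NS(=O)(=O)c3cc(N(C)S(C)(=O)=O)ccc3N2)c1=O` share one core. In an in vitro ADME assay on microsomes from liver (Macaca mulatta) for metabolic stability, tested at 5 uM (on this read-out higher numbers stand for a longer-lived compound and lower numbers for a shorter-lived compound), compound 1 gives 0.107 h, compound 2 gives 0.283 h and compound 3 gives 0.167 h. Compound 2 holds the highest of the three numbers, though its gap to compound 3 lies within the scatter, while its gap to compound 1 lies beyond it. Compound 4 `CC(C)(C)CCn1nc(CC(C)(C)C)c(O)c(C2=NS(=O)(=O)c3cc(NS(C)(=O)=O)ccc3N2)c1=O` differs from compound 2 by neopentyl in place of 2-methylprop-1-en-1-yl on an aromatic carbon. Going by the values given here, only one measured step bears on this carbon: a 2.6-fold higher number from compound 1 to compound 2 (0.42 log units; beyond the scatter). Compound 4 removes the double bond that this step brought in, so compound 4 is expected to show a modest drop, a 1.4-fold lower number from compound 2 to compound 4 (0.15 log units; within the scatter), estimated at 0.2 h with a range from 0.08 h to 0.5 h.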

Compound 4, half-life: 0.117 h
Estimate against measurement, compound 4: 1.7-fold (0.23 log units) above; measured number inside the range.
By their numbers in this assay, from the lowest: compounds 1, 4, 3 and 2 (each within the scatter of the next, the first and the last beyond it).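

In this assay, moving to neopentyl on this aromatic carbon gives a 2.4-fold lower number from compound 2 to compound 4 (0.38 log units; beyond the scatter) and so does not keep the higher number of compound 2 once the double bond is gone. With a 1.1-fold higher number from compound 1 to compound 4 (0.04 log units; within the scatter) as the other step, neopentyl and cyclopropyl cannot be told apart here, leaving 2-methylprop-1-en-1-yl alone in standing out among these three groups. No measured property is available to explain this difference.

On these data alone, whether the double bond alone or the wider change in the chain matters stays open, and an isobutyl group on this carbon would separate the two. As far as these compounds go, how an amine at this carbon would behave is equally open.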